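A few compounds are considered here, and "the series" means these few. Any claim that something is new, unique, unknown or untested is made for them only; others in the source may bear on it.

Of the compounds shown here, three built on one shared core have been measured in a functional assay on SK-OV-3 cells (Homo sapiens) for antiproliferative activity, read by MTT assay; a higher number here means a weaker inhibitor, a lower number a stronger inhibitor. Compound 1 `COC(=O)N1CCCc2cc(S(=O)(=O)N3CC(c4ccccc4)NC3=O)ccc21` gives 3480 nM. Compound 2 `CCOC(=O)N1CCCc2cc(S(=O)(=O)N3CC(c4ccccc4)NC3=O)ccc21` gives 2880 nM, and compound 3 `O=C(OCCCl)N1CCCc2cc(S(=O)(=O)N3CC(c4ccccc4)NC3=O)ccc21` gives 9800 nM. Among these three numbers compound 1 stands second highest, nearest to compound 2 and furthest from compound 3. The step of a 1.2-fold lower number from compound 1 to compound 2 (0.08 log units; within the scatter) lies within the scatter, whereas a 2.8-fold higher number from compound 1 to compound 3 (0.45 log units; beyond the scatter) and a 3.4-fold higher number from compound 2 to compound 3 (0.53 log units; beyond the scatter) are modest but beyond it.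

Compound 4 `NC(=O)N1CCCc2cc(S(=O)(=O)N3CC(c4ccccc4)NC3=O)ccc21` has not yet been measured in this assay. It differs from compound 1 by amino in place of methoxy on a carbonyl carbon. For the measured compounds named here, none of the measured steps touches the carbonyl carbon itself; they alter only what hangs on the oxygen next to the carbonyl group, and even the largest of them, a 2.8-fold higher number from compound 1 to compound 3 (0.45 log units; beyond the scatter), is modest. Going by the values given here, there is no direct precedent for exchanging methoxy for amino here. On that basis only a small step is expected, its direction uncertain, estimated as a 1.1-fold higher number from compound 1 to compound 4 (0.06 log units; within the scatter). Compound 4 is therefore expected to give about 4000 nM in this assay, with a likely range from 1500 nM to 11000 nM.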

Compound 4, half-maximal inhibitory concentration: > 20000 nM
Compound 4: no number, only a limit (the forecaster's own chance of this, stated with the estimate: 5%); middle value at least 5.0-fold (0.69 log units) from the limit.
By their numbers in this assay, from the lowest: compounds 2 and 1 (each within the scatter of the next); then compound 3. At a limit, above all of these: compound 4.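

In this assay compound 4 gives only a limit of the assay, > 20000 nM. The carbonyl carbon proves more sensitive than the chain on the oxygen: the steps there were no larger than modest, whereas this exchange gives an at least 5.7-fold higher number from compound 1 to compound 4 (0.75 log units; beyond the scatter) and an at least 6.9-fold higher number from compound 2 to compound 4 (0.84 log units; beyond the scatter). Against the weakest of the earlier compounds the result is less clear, with an at least 2.0-fold higher number from compound 3 to compound 4 (0.30 log units; that floor lies within the scatter), so this floor alone does not set the two apart.

The compounds shown leave open how far the true value of compound 4 lies past its limit. They also leave open whether the change depends on the amino group itself or on removing the oxygen from the carbonyl carbon, which methylamino, dimethylamino or a plain methyl on that carbon could help to separate.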